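Amino Added to the Core of a Chloromethylbenzyl Scaffold

This account rests on a few compounds, and the source may have more. Where it says the series, first, only, none or still open, it means among the compounds named here.

The study begins with compound 1 `ClCc1ccc(Cn2cnc3c(Cl)ncnc32)cc1`, for which a functional assay on HT-29 cells (Homo sapiens) for cytotoxicity, read by sulforhodamine B assay, with a stated time of 48 h (on this read-out higher numbers stand for weaker inhibition of growth and lower numbers for stronger inhibition of growth), reports "not determined" (no result reported), so compound 1 stands without a number in this assay. Among the compounds with values here, the only measured neighbour is compound 2 `Nc1nc(Cl)c2ncn(Cc3ccccc3CCl)c2n1`, which shares the amino group on the core and differs from the target compound only in where the chloromethyl group sits on the benzyl ring; in this assay compound 2 gives 3890 nM. The target is compound 3 `Nc1nc(Cl)c2ncn(Cc3ccc(CCl)cc3)c2n1`, reached from compound 1 by amino in place of hydrogen on an aromatic carbon. Within the data shown here, no measured step accompanies this change, and with no number for compound 1 its size and direction cannot be read from the data; the author therefore expects only a value in the range of compound 2 rather than a defined shift. Compound 3 is estimated at 3500 nM, with a range from 900 nM to 14000 nM.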

Compound 3, concentration for 50% growth inhibition: 9770 nM
The estimate for compound 3 lay 2.8-fold (0.45 log units) below the measured number; low and high end bracket the measured number.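

No step can be read from compound 1 to compound 3: in this assay compound 1 stands without a number. The compounds shown leave open what amino in place of hydrogen does to growth inhibition on this core. No evidence at hand bears on the result.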